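A few compounds are considered here, and "the series" means these few. Any claim that something is new, unique, unknown or untested is made for them only; others in the source may bear on it.

In a functional assay on A549 cells (Homo sapiens) for cytotoxicity, read by MTT assay, with a stated time of 72 h (a higher number here means a weaker inhibitor, a lower number a stronger inhibitor), compound 1 (`CCN(CC)Cc1ccc2nc(NC(=O)N/N=C/c3cn(Cc4ccc(C(C)(C)C)cc4)c4ccccc34)sc2c1`) gives 1710 nM. Going by the values given here, compound 2 (`CN(C)Cc1ccc2nc(NC(=O)N/N=C/c3cn(Cc4ccc(C(C)(C)C)cc4)c4ccccc34)sc2c1`) gives 1850 nM, so these two sit together at the low end of the three numbers measured so far. Compound 3 (`CC1CCN(Cc2ccc3nc(NC(=O)N/N=C/c4c[nH]c5ccccc45)sc3c2)CC1`) gives 3580 nM, the number furthest from compound 1.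

Compound 4 (`CCN(CC)Cc1ccc2nc(NC(=O)N/N=C/c3cn(Cc4ccc(C)cc4)c4ccccc34)sc2c1`) has not been measured. It keeps all of compound 1 except one group: methyl in place of tert-butyl on an aromatic carbon. Methyl replaces tert-butyl on an aromatic carbon, turning 4-(tert-butyl)benzyl into 4-methylbenzyl.

Among the compounds with values here, no measured step touches this group. Within the data shown here, the one single-place step, a 1.1-fold higher number from compound 1 to compound 2 (0.03 log units; within the scatter), swaps diethylamino for dimethylamino elsewhere in the molecule, so it says little here. Compound 3, at 3580 nM, has no 4-(tert-butyl)benzyl group at all, but it also differs in its amine, so it is only a loose guide.

A small step towards a higher number is therefore expected in this assay, estimated as a 1.3-fold higher number from compound 1 to compound 4 (0.11 log units; within the scatter), and it may not clear the scatter. For compound 4 the estimated value is 2200 nM, with an expected range from 1000 nM to 4800 nM.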

Compound 4, half-maximal inhibitory concentration: 1510 nM
Beside the measured number, compound 4's estimate is 1.5-fold (0.16 log units) above it; the range from low to high includes it.
By their numbers in this assay, from the lowest: compounds 4, 1, 2 and 3 (each within the scatter of the next, the first and the last beyond it).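

Swapping tert-butyl for methyl on this aromatic carbon, a change from 4 heavy atoms to 1, gives the first measured step at this position in this assay (a 1.1-fold lower number from compound 1 to compound 4 (0.05 log units; within the scatter)). So, with the diethylamino amine in place, the number does not depend on keeping the full tert-butyl group, and 4-methylbenzyl serves as well as 4-(tert-butyl)benzyl here. Nothing measured here accounts for this result.

On these data alone, it remains open whether a methoxy group, a chlorine atom or a carboxylic acid on the same aromatic carbon would also leave the number unmoved, and whether the swap would behave alike with the dimethylamino amine of compound 2. Compound 3 lacks the substituted benzyl group but also carries a different amine, so the effect of removing that group alone stays unresolved.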